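A few compounds are considered here, and "the series" means these few. Any claim that something is new, unique, unknown or untested is made for them only; others in the source may bear on it.

Measured so far, in a functional assay on cells for agonist activity at Glucose-dependent insulinotropic receptor (Homo sapiens), read by a luciferase reporter, with a stated time of 4 h; a lower number here means that less compound is needed, a higher number that more compound is needed for the effect:
compound 1 `CS(=O)(=O)c1ccc2c(c1)CCN2c1ncnc2c(C3CCN(c4ncccn4)CC3)coc12` gives 512 nM
compound 2 `CC(C)(C)OC(=O)N1CCC(c2noc3c(Nc4ccc(S(C)(=O)=O)cc4F)ncnc23)CC1` gives 353 nM

Of these two numbers, compound 1 carries the higher one, but the gap between compound 1 and compound 2 falls within the usual scatter of this assay, so the two cannot really be told apart on the evidence at hand.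

Compound 3 `COc1cnc(N2CCC(c3coc4c(N5CCc6cc(S(C)(=O)=O)ccc65)ncnc34)CC2)nc1` has not yet been measured. It differs from compound 1 in a single place: methoxy in place of hydrogen on an aromatic carbon; read one bond further out, the pyrimidin-2-yl group becomes 5-methoxypyrimidin-2-yl. Going by the values given here, no measured pair shows what such a change does in this assay, so no step size can be read from the data. With nothing to point to a large shift, the step from compound 1 to compound 3 is expected to be a 1.3-fold lower number from compound 1 to compound 3 (0.11 log units; within the scatter), staying inside the scatter. Compound 3 is therefore estimated at 400 nM, with a range from 130 nM to 1200 nM.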

Compound 3, half-maximal effective concentration: 310 nM
The estimate for compound 3 lay 1.3-fold (0.11 log units) above the measured number; the range from low to high includes it.
By their numbers in this assay, from the lowest: compounds 3, 2 and 1 (each within the scatter of the next).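

In this assay, going by these compounds alone, turning the pyrimidin-2-yl group into 5-methoxypyrimidin-2-yl gives a 1.7-fold lower number from compound 1 to compound 3 (0.22 log units; within the scatter), the only single-place step available so far. This shows that a methoxy group can stand in place of hydrogen on this aromatic carbon, para to a large group, without a change that can be told apart from the ordinary spread of repeated measurements. Nothing at hand explains this result or says how the methoxy group acts at this carbon.

From the compounds shown here alone, one substituent at one carbon cannot define what this position accepts, so it remains open whether an amine, a carboxylic acid or a longer chain such as butoxy would move the number beyond the scatter. Going by these compounds, it also remains open whether methoxy would behave the same way on another carbon of that ring.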